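The compounds below may be only part of what the source reports. "The series", "measured", "known", "first", "only" and "open" are said of these compounds alone.

Compound 1, with the structure `O=C(N/N=C/c1ccccc1)c1cnccn1`, is a hydrazone built on a shared core, and in an ADME assay on J774 cells (Mus musculus) for cytotoxicity, read by MTT assay, with a stated time of 48 h, tested at 100 ug/mL (a higher number here means a weaker effect of the compound at the concentration tested, a lower number a stronger effect), compound 1 gives 75%. Two measured neighbours share that core. Compound 2, `O=C(N/N=C/c1ccccc1Cl)c1cnccn1`, carries a chloro group and gives 66% in this assay; compound 3, `O=C(N/N=C/c1cccc(Br)c1)c1cnccn1`, carries a bromo group and gives 100%. Among these three numbers compound 1 stands second highest: the change to compound 2 is a number 9 percentage points lower from compound 1 to compound 2 (within the scatter), which stays within the scatter, while the change to compound 3 is a number 25 percentage points higher from compound 1 to compound 3 (beyond the scatter), a modest rise beyond the scatter.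

Compound 4, `O=C(N/N=C/c1ccc(Br)cc1)c1cnccn1`, is not yet measured. Compared with compound 1 the difference is bromo in place of hydrogen on an aromatic carbon. Among the compounds with values here, the step that bears most directly on it is the one to compound 3, where a bromo group entering on the same kind of ring carbon gave the modest rise just described; the step to compound 2 shows that a halogen can also leave the number unchanged. On this basis the step to compound 4 is expected to be a modest rise, estimated as a number 13 percentage points higher from compound 1 to compound 4 (beyond the scatter). Compound 4 is therefore expected to give about 88% in this assay, with a range from 70% to 100%.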

Compound 4, a percentage reported as activity, at one concentration (the size of the read-out at that concentration, not a potency): 100%
The estimate for compound 4 lay 12 percentage points below the measured number, and the stated range covers the measured number.
By their numbers in this assay, from the lowest: compounds 2 and 1 (each within the scatter of the next); then compounds 3 and 4 (each within the scatter of the next).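

Putting bromo in place of hydrogen on this aromatic carbon, para to a large group, gives a number 25 percentage points higher from compound 1 to compound 4 (beyond the scatter) in this assay and so matches in size the earlier step, a number 25 percentage points higher from compound 1 to compound 3 (beyond the scatter), where bromo sits on another carbon of the same ring. The rise with bromo therefore does not depend on one single ring carbon, and since a higher number here means a weaker effect at the concentration tested, both bromo compounds act less strongly on the cells than compound 1 does, while compound 2, with chloro, goes against any wider rule for halogens, its step being a number 9 percentage points lower from compound 1 to compound 2 (within the scatter). Nothing in the data shown gives a reason why bromo shifts the number at either carbon.

On these data alone, whether chloro on the carbon that carries bromo in compound 4 would bring a similar rise remains open. Also open, as far as these compounds go, is how a group of another kind on that carbon, such as a methoxy group, an amine or a carboxylic acid, would change the number in this assay.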